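A few compounds are considered here, and "the series" means these few. Any claim that something is new, unique, unknown or untested is made for them only; others in the source may bear on it.

Measured so far:
Compound 1, `O=C(Nc1c(F)cc(F)cc1F)N(Cc1ccc(-c2cccs2)cc1)C1CCCCCC1`: in a functional assay on a cell-free system (plasma) with sterol O-acyltransferase, Soat (Rattus norvegicus) as the target (a higher number here means that more compound is needed for the effect, a lower number that less compound is needed), compound 1 gives > 1 mg/kg, which is a limit of the assay.
Compound 2, `Cc1cc(C)c(NC(=O)N(Cc2cccc(-c3nnnn3C)c2)C2CCCCCC2)c(C)c1`: in this assay compound 2 gives > 1 mg/kg, again a limit.
Compound 3, `Cc1cc(C)c(NC(=O)N(Cc2ccc(-c3cccs3)cc2)C2CCCCCC2)c(C)c1`: in this assay compound 3 gives 0.28 mg/kg.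

Within the data shown here, compound 3 thus stands as the only real number among the three; the other two sit at the limit of > 1 mg/kg in this assay, at which 2 of the 3 values shown sit. Among the measured compounds shown here, the single measured step, an at least 3.5-fold lower number from compound 1 to compound 3 (0.55 log units; beyond the scatter), concerns the aryl group on the amide-type nitrogen and says nothing about the ring at the other end of the molecule. Compound 4, `Cc1cc(C)c(NC(=O)N(Cc2ccc(-c3cc[nH]n3)cc2)C2CCCCCC2)c(C)c1`, differs from compound 3 in exactly that other ring: 1H-pyrazol-3-yl in place of thiophen-2-yl on an aromatic carbon. For the measured compounds named here, no measured step bears on this change, so the expectation rests only on the fact that compound 3 is the one compound with a number and that the rest of its structure is kept. The expected step of a 2.1-fold higher number from compound 3 to compound 4 (0.33 log units; beyond the scatter) is therefore small and uncertain. For compound 4 the estimate in this assay is 0.6 mg/kg, with a range from 0.2 mg/kg to 3 mg/kg.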

Compound 4, dose for half-maximal effect: > 1 mg/kg
Compound 4 was reported as a limit (the forecaster's own chance of this, stated with the estimate: 40%); middle value at least 1.6-fold (0.22 log units) away from the limit.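

In this assay, the group on the aromatic carbon para to a large group proves to matter: with the rest of compound 3 kept, 1H-pyrazol-3-yl in place of thiophen-2-yl gives an at least 3.5-fold higher number from compound 3 to compound 4 (0.55 log units; beyond the scatter). Among these compounds, the earlier step, an at least 3.5-fold lower number from compound 1 to compound 3 (0.55 log units; beyond the scatter), concerned only the aryl group on the amide-type nitrogen, so this is the first measured change at the other end of the molecule, one that keeps the ring size and heavy-atom count but adds a hydrogen-bond donor. The result for compound 4 is a limit, and it joins the other compounds there: the limit of > 1 mg/kg in this assay, at which 3 of the 4 values shown sit.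

Whether the hydrogen-bond donor or the second ring nitrogen accounts for the step remains open, and a pyrazole with a methyl group on its ring nitrogen would separate the two. On these data alone, how a phenyl ring, a pyridine or a carboxylic acid would fare at this position also remains open.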